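Phenyl for Piperidin-1-yl in a Growth Inhibition Test

This account rests on a few compounds, and the source may have more. Where it says the series, first, only, none or still open, it means among the compounds named here.

Compound 1 `Cc1cc(=O)c2c(O)cc(O)c([C@H]3CCN(C)C[C@H]3OC(=O)c3ccco3)c2o1`: 20%
Compound 2 `CCN(CC)Cc1c(O)c([C@H]2CCN(C)C[C@H]2O)c2oc(C)cc(=O)c2c1O`: 24%
Compound 3 `Cc1cc(=O)c2c(O)c(CN3CCC(N4CCCCC4)CC3)c(O)c([C@H]3CCN(C)C[C@H]3O)c2o1`: 25%

All three numbers come from a functional assay on MCF7 cells (Homo sapiens) for inhibition, read by MTT assay, with a stated time of 48 h, tested at 10 uM; on this read-out lower numbers stand for less inhibition of growth and higher numbers for more inhibition of growth at the one concentration tested. Compound 3 (25%) cannot be told apart from compound 2 (24%) or compound 1 (20%) since all three lie within the usual scatter of repeated measurements. The next compound to be tested is compound 4 `Cc1cc(=O)c2c(O)c(CN3CCC(c4ccccc4)CC3)c(O)c([C@H]3CCN(C)C[C@H]3O)c2o1` and it differs from compound 3 in one place. It carries phenyl in place of piperidin-1-yl on a saturated ring carbon and that carbon sits three ring bonds from the ring nitrogen.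

Among the compounds with values here, no two measured compounds differ in only one place, so nothing measured so far shows directly what this swap does. The three measured compounds do differ from one another in their structures, yet their numbers stay close together. On that evidence a single swap is expected to move the number little, and no direction can be firmly argued. The expected change is a number 2 percentage points higher from compound 3 to compound 4 (within the scatter) and this is no step beyond the scatter. The estimate for compound 4 is 27% and it is expected to lie between 12% and 47%.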

Compound 4, percent growth inhibition at one concentration: 23%
Compound 4: middle estimate off by 4 percentage points, on the high side; low and high end bracket the measured number.
By their numbers in this assay, from the lowest: compounds 1, 4, 2 and 3 (each within the scatter of the next).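

In this assay, within the data shown here, swapping in phenyl in place of piperidin-1-yl on a saturated ring carbon, three ring bonds from the ring nitrogen, gives the first direct one-place comparison in this set: a number 2 percentage points lower from compound 3 to compound 4 (within the scatter). Both groups have 6 heavy atoms and one six-membered ring, but piperidin-1-yl is non-aromatic and has 1 hydrogen-bond acceptor, whereas phenyl is aromatic, is made of carbon only and has 0 hydrogen-bond acceptors, and at the one concentration tested this test cannot tell the two compounds apart. No measurement shown here offers an explanation for this outcome.

On these data alone, it remains open whether a quite different group on this same ring carbon, such as a primary amine, a carboxylic acid or a longer alkyl chain, would give a step beyond the usual scatter. As far as these compounds go, it also remains open whether compound 3 and compound 4 could be told apart at other concentrations, since a single-concentration reading shows only how much growth is inhibited at that one concentration.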